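The source may report more compounds than this note shows. Statements on the series, on what has been measured and on what is new or still open speak of the compounds shown alone.

Of the compounds shown here, three sharing one core have been tested in an in vitro ADME assay on microsomes from liver (Rattus norvegicus) for metabolic stability (a higher number here means faster removal of the compound, a lower number slower removal), and they differ only in the group on the nitrogen. Compound 1 `Nc1ccnc(Nc2ccc(Oc3ccc(Cl)cc3)cc2)c1` gives > 399 mL.min-1.g-1, which is a limit of the assay and not a number. Compound 2 `Nc1cnnc(Nc2ccc(Oc3ccc(Cl)cc3)cc2)c1` gives > 399 mL.min-1.g-1, again a limit. Compound 3 `Nc1nsc(Nc2ccc(Oc3ccc(Cl)cc3)cc2)n1` gives < 14 mL.min-1.g-1, also a limit. As far as these compounds go, it is alone at the low end of the three, so its true number remains unknown.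

Compound 4 `Nc1nnc(Nc2ccc(Oc3ccc(Cl)cc3)cc2)s1` has the same atoms as compound 3, joined differently: 5-amino-1,3,4-thiadiazol-2-yl in place of 3-amino-1,2,4-thiadiazol-5-yl on a nitrogen on an aromatic ring. In words, 5-amino-1,3,4-thiadiazol-2-yl takes the place of 3-amino-1,2,4-thiadiazol-5-yl on a nitrogen on an aromatic ring.

Two measured steps at this same place bear on the change, and both are large: an at least 28-fold lower number from compound 1 to compound 3 (1.45 log units; beyond the scatter), and an at least 28-fold lower number from compound 2 to compound 3 (1.45 log units; beyond the scatter). A third, a step that the two limits leave unreadable from compound 1 to compound 2, cannot be sized. These steps show that a swap here can move the number a long way, but none of them links two thiadiazoles. A small upward move is expected, with a wide margin, and the estimated step is an at least 2.1-fold higher number from compound 3 to compound 4 (0.33 log units; beyond the scatter). Compound 4 is estimated at 30 mL.min-1.g-1, with an expected range from 10 mL.min-1.g-1 to 150 mL.min-1.g-1.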

Compound 4, intrinsic clearance in microsomes: < 14 mL.min-1.g-1
Compound 4: no number, only a limit; the forecaster's own chance of this, stated with the estimate: 35%; at least 2.1-fold (0.33 log units) between middle value and limit.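

In this assay the result for compound 4 is again a limit of the assay and not a number, so the step between compound 3 and compound 4 cannot be read. The steps that can be read are both large and beyond the scatter: an at least 28-fold lower number from compound 2 to compound 4 (1.45 log units; beyond the scatter), and an at least 28-fold lower number from compound 1 to compound 4 (1.45 log units; beyond the scatter). The low result of compound 3 is therefore not confined to one arrangement of the ring atoms, since 3-amino-1,2,4-thiadiazol-5-yl and 5-amino-1,3,4-thiadiazol-2-yl on this nitrogen both give it, and the four compounds now split into two pairs with no readable order inside the low pair: the limit of < 14 mL.min-1.g-1 in this assay, at which 2 of the 4 values shown sit.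

As far as these compounds go, how far the true numbers of compound 3 and compound 4 lie from that limit stays open, and so does whether the two thiadiazoles differ at all. Also open, from the compounds shown here alone, is whether the low result follows the thiadiazole ring or its amine, which a thiadiazole with a methyl group in place of the amine, or an oxadiazole ring that keeps the amine, could begin to separate.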